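The compounds below may be only part of what the source reports. "The series", "measured", "known", "first", "only" and "open" are said of these compounds alone.

Measured in a functional assay on the whole organism (strain Kunming) with Mus musculus as the target, with a stated time of 0.5 h; a lower number here means that less compound is needed, a higher number that more compound is needed for the effect:

Compound 1 `COc1cc(OC)c(OC)cc1/C=C/COC(=O)/C=C/c1cc(OC)c(OC)c(OC)c1OC`: > 200 mg/kg
Compound 2 `COc1cc(OC)c(OC)cc1/C=C/COC(=O)/C=C/c1ccc(Br)cc1`: > 300 mg/kg

Both entries are limits of this assay, not exact numbers. Compound 2 stands only at its limit of > 300 mg/kg.

Compound 3 `COc1cc(OC)c(OC)cc1/C=C/COC(=O)/C=C/c1ccc(F)cc1` keeps the rest of compound 2 but carries fluoro in place of bromo on an aromatic carbon, para to a large group: fluoro in place of bromo on an aromatic carbon.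

For the measured compounds named here, no measured pair shows the size of such a swap. The step expected in this assay is therefore none beyond the scatter, with no direction predicted, and is estimated as a number no higher from compound 2 to compound 3 (the limit leaves the size open). For compound 3 the expected value is 300 mg/kg, with an estimated range of 150 mg/kg to 600 mg/kg.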

Compound 3, dose for half-maximal effect: > 300 mg/kg
Compound 3 was reported as a limit (the forecaster's own chance of this, stated with the estimate: 60%); the middle value lies on the limit itself.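

No step can be read from compound 2 to compound 3, because both are reported only as the same limit: the limit of > 300 mg/kg in this assay, at which 2 of the 3 values shown sit. The compounds shown leave open whether bromo and fluoro differ here at all, and what dose any of them needs for the effect.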